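Working notes: dimethylamino gives way to methyl

The source may report more compounds than this note shows. Statements on the series, on what has been measured and on what is new or still open speak of the compounds shown alone.

In an ADME assay on HPC cells (Homo sapiens) for cytotoxicity, with a stated time of 24 h (on this read-out higher numbers stand for lower toxicity in this test and lower numbers for higher toxicity in this test), compound 1 `O=C1/C(=C/c2ccccc2)CCC/C1=C\c1cccc([N+](=O)[O-])c1` gives 14000 nM and compound 2 `O=C1/C(=C/c2ccc(F)cc2)CCC/C1=C\c1cccc([N+](=O)[O-])c1` gives 38000 nM. Compound 3 `CN(C)c1ccc(/C=C2\CCC/C(=C\c3cccc([N+](=O)[O-])c3)C2=O)cc1` reads > 400000 nM, which is a limit of the assay and not a number.

Compound 4 `Cc1ccc(/C=C2\CCC/C(=C\c3cccc([N+](=O)[O-])c3)C2=O)cc1` has not yet been measured in this assay. It differs from compound 3 by methyl in place of dimethylamino on an aromatic carbon, with methyl in place of dimethylamino on an aromatic carbon, para to a large group.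

Two measured steps lead into compound 3: an at least 28-fold higher number from compound 1 to compound 3 (1.45 log units; beyond the scatter) and an at least 10-fold higher number from compound 2 to compound 3 (1.02 log units; beyond the scatter). Both are large, and both rest on the limit. By contrast, a 2.7-fold higher number from compound 1 to compound 2 (0.43 log units; beyond the scatter) is only modest. Among these three compounds, only the one carrying dimethylamino reaches the limit, so compound 4, which lacks that group, is expected to fall near compound 1 and compound 2. The expected change is an at least 16-fold lower number from compound 3 to compound 4 (1.20 log units; beyond the scatter), a large step towards a lower number. For compound 4 the estimate is 25000 nM, with an expected range of 8000 nM to 90000 nM.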

Compound 4, half-maximal cytotoxic concentration: 192000 nM
For compound 4 the middle estimate is 7.7-fold (0.89 log units) below the measured one; measured number above the stated range.
By their numbers in this assay, from the lowest: compound 1; then compound 2; then compound 4. At a limit, above all of these: compound 3.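

At this position, para to a large group, a raised number in this assay does not depend on dimethylamino: methyl also gives a 14-fold higher number from compound 1 to compound 4 (1.14 log units; beyond the scatter) and a 5.1-fold higher number from compound 2 to compound 4 (0.70 log units; beyond the scatter). Among the compounds with real numbers, the order runs from hydrogen through fluoro to methyl, so the modest fluoro step is not the ceiling for a small group here. Methyl in place of dimethylamino gives an at least 2.0-fold lower number from compound 3 to compound 4 (0.31 log units; beyond the scatter), but the full size of that step cannot be read, since the entry for compound 3 is a limit and not a number: the limit of > 400000 nM in this assay, at which 1 of the 4 values shown sits.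

The compounds shown do not tell what in methyl or dimethylamino sets these numbers. As far as these compounds go, whether methoxy, a primary amine or a longer chain such as ethyl at this position would follow methyl or dimethylamino remains open.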